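The compounds below may be only part of what the source reports. "The series", "measured", "known", "first", "only" and "open" are said of these compounds alone.

Compound 1, `CCCCc1c(-c2ccc(O)c(O)c2)oc2cc(O)cc(O)c2c1=O` — in a functional assay, read by fluorescence (a lower number here means a stronger inhibitor, a higher number a weaker inhibitor), compound 1 gives 2720 nM
Compound 2, `O=c1cc(/C=C/c2ccc(O)c(O)c2)oc2c(O)c(O)ccc12` — compound 2 gives 193 nM
Compound 3, `COc1ccc2c(=O)cc(/C=C/c3ccc(O)c(O)c3)oc2c1OC` — compound 3 gives 368 nM

Among these three numbers, compound 1 has the highest, which in this assay means the weakest inhibitor of the set. The nearest of the other two is compound 3, and the furthest is compound 2; both of those differences lie beyond the usual scatter of repeated measurements, so compound 1 stands apart as the weakest of the three.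

The step to follow leads from compound 1 to compound 4, `CCCCCCCCCCc1c(-c2ccc(O)c(O)c2)oc2cc(O)cc(O)c2c1=O`. The two structures differ in a single place: hexyl in place of hydrogen on a saturated chain carbon, four bonds along the chain from an aromatic carbon. Within the data shown here, no pair of measured compounds in this set differs in a comparable way, so the numbers give no direct guide to the size or direction of such a change. On that basis the expected step of a 1.1-fold lower number from compound 1 to compound 4 (0.04 log units; within the scatter) is small, with no clear direction beyond the scatter. Compound 4 is expected to give about 2500 nM in this assay, within a wide range from 800 nM to 8000 nM.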

Compound 4, half-maximal inhibitory concentration: 4850 nM
The estimate for compound 4 lay 1.9-fold (0.29 log units) below the measured number; the measured number falls inside the stated range.
By their numbers in this assay, from the lowest: compounds 2 and 3 (each within the scatter of the next); then compounds 1 and 4 (each within the scatter of the next).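

In this assay hexyl in place of hydrogen on a saturated chain carbon, four bonds along the chain from an aromatic carbon, gives a 1.8-fold higher number from compound 1 to compound 4 (0.25 log units; within the scatter) and so leaves the two compounds indistinguishable in this measurement. Among these compounds, this is the first pair here that differs in only one place, and it shows that the chain of compound 1 can carry these six extra carbons with no change that stands out from the usual scatter of repeated measurements. Nothing available here speaks to the reason for this result.

From the compounds shown here alone, what a chain ending in an amine or a carboxylic acid would do at this position remains open. So does the effect of a much shorter chain, such as ethyl, on the same core.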